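This account rests on a few compounds, and the source may have more. Where it says the series, first, only, none or still open, it means among the compounds named here.

Three compounds sharing one core were tested in an ADME assay on THP-1 cells (Homo sapiens) for cytotoxicity, read by MTT assay, with a stated time of 5 days (on this read-out higher numbers stand for weaker inhibition and lower numbers for stronger inhibition), which reports how much of a substance is needed to cut the growth of a human immune-type cell line in half. Compound 1 `COc1ccc([C@H]2SCC(=O)N2NC(=O)c2nccnc2N)cc1OC` gives 85.4 ug/mL in this assay. For compound 2 `Cc1cnc(C(=O)NN2C(=O)CS[C@@H]2c2ccc([N+](=O)[O-])cc2)cn1` the assay returns only a limit, > 100 ug/mL, so no exact number is known. Compound 3 `O=C(NN1C(=O)CS[C@@H]1c1ccc(Cl)cc1)c1cnccn1` likewise sits at a limit, > 100 ug/mL, which means it stands at the limit of > 100 ug/mL in this assay, at which 2 of the 3 values shown sit, and no finer placing is possible. With two of three results at the ceiling and the third not far below it, none of the three shows marked toxicity toward these cells.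

The next compound, compound 4 `O=C(NN1C(=O)CS[C@@H]1c1ccc([N+](=O)[O-])cc1)c1cnccn1`, differs from compound 3 only in one spot: nitro in place of chloro on an aromatic carbon. The same nitro group is also present in compound 2, which sits at a limit, > 100 ug/mL. For the measured compounds named here, nothing among the measured compounds points to a change large enough to leave the scatter. The step that the limit leaves unreadable from compound 3 to compound 4 is therefore expected to be none beyond the scatter, with the result most likely again a limit. Compound 4 is estimated at 120 ug/mL, in a range from 60 ug/mL to 250 ug/mL.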

Compound 4, half-maximal inhibitory concentration: 97.7 ug/mL
Compound 4: the middle estimate sits 1.2-fold (0.09 log units) above what was measured; measured number inside the range.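

With nitro in place of chloro on an aromatic carbon, para to a large group, compound 4 gives 97.7 ug/mL in this assay, an exact number rather than a limit. Nitro in place of chloro gives an at least 1.0-fold lower number from compound 3 to compound 4 (0.01 log units; that floor lies within the scatter), and hydrogen in place of methyl on an aromatic carbon gives an at least 1.0-fold lower number from compound 2 to compound 4 (0.01 log units; that floor lies within the scatter). Each of these steps is only a floor, so neither shows a change beyond the scatter, and the true size of both cannot be read: the limit of > 100 ug/mL in this assay, at which 2 of the 4 values shown sit.

As far as these compounds go, whether an amine or a carboxylic acid on this same aromatic carbon, or a longer chain in place of the methyl of compound 2, would move the number beyond the scatter remains open. The compounds shown also leave open what change to the shared core, if any, would make it clearly toxic to these cells.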